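Dropping the Benzyloxy Group from a Nitrobenzyl Indazole

The source may report more compounds than this note shows. Statements on the series, on what has been measured and on what is new or still open speak of the compounds shown alone.

Going by the values given here, compound 1, `O=[N+]([O-])c1cc(OCc2ccccc2)ccc1CNc1cc(C(F)(F)F)cc2[nH]ncc12`, stands lowest of the two compounds measured so far. In an assay for inhibition of Indoleamine 2,3-dioxygenase 1 (Homo sapiens), with stated times of 10 min and 60 min, tested at 100 uM (on this read-out higher numbers stand for a stronger effect at the one concentration tested and lower numbers for a weaker effect), compound 1 gives 20%. Among the compounds with values here, the only other measured compound, compound 2, `COc1cc(CNc2cc(Br)cc3[nH]ncc23)c([N+](=O)[O-])cc1OC`, gives 79% in this assay, a gap well beyond the usual scatter of repeated runs. Compound 2 differs from compound 1 in several places at once, so its higher number cannot be tied to any single change.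

Compound 3, `O=[N+]([O-])c1ccccc1CNc1cc(C(F)(F)F)cc2[nH]ncc12`, differs from compound 1 in one place only: hydrogen in place of benzyloxy on an aromatic carbon. Within the data shown here, no measured pair shows the effect of this change on its own, so the expectation for compound 3 rests on compound 1 alone. With nothing pointing strongly either way, only a small step is expected in this assay, one that may not exceed the usual scatter in either direction. The step expected here is a number 5 percentage points higher from compound 1 to compound 3 (within the scatter). Compound 3 is therefore estimated to give about 25% in this assay, with a plausible range from 5% to 55%.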

Compound 3, a percentage reported as inhibition, at one concentration (the size of the read-out at that concentration, not a potency): 76%
The estimate for compound 3 lay 51 percentage points below the measured number, and the stated range ends below it.
By their numbers in this assay, from the lowest: compound 1; then compounds 3 and 2 (each within the scatter of the next).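

Taking the benzyloxy group off this aromatic carbon, the one meta to the nitro group, and leaving hydrogen there gives a number 56 percentage points higher from compound 1 to compound 3 (beyond the scatter) in this assay, so the carbon is a place where the choice of substituent matters a great deal, and the benzyloxy group, with its extra aromatic ring, is not needed for the effect seen at the one concentration tested. Going by these compounds alone, this is the first pair that differs in one place only, which means this step, unlike the gap to the other compound in the set, can be tied to a single change on the shared core. Nothing measured here explains why the number moves so strongly with this change. The compounds shown leave open whether only the benzyloxy group is poorly accepted at this carbon or whether any substituent there would lower the number, and a hydroxyl group, an amine or a short ethoxy chain in the same place would help tell these apart. This single pair also leaves open whether the step would keep its size on a core carrying something other than trifluoromethyl.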